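Second sulfonamide on the shared core of compound 3

The source may report more compounds than this note shows. Statements on the series, on what has been measured and on what is new or still open speak of the compounds shown alone.

Working notes on the sulfonamide series. Compound 1 `C=Cc1ccc(S(=O)(=O)Nc2ccc3oc(-c4ccccc4)nc3c2)cc1` gives in an assay on cells for inhibition of HSP60/HSP10 (Homo sapiens), with a stated time of 60 min (a higher number here means a weaker inhibitor, a lower number a stronger inhibitor), only a limit, > 100000 nM. Compound 2 `O=S(=O)(Nc1ccc2oc(-c3ccccc3)nc2c1)c1cccc(F)c1` also returns a limit, > 100000 nM. Compound 3 `O=S(=O)(Nc1ccc2oc(-c3ccccc3)nc2c1)c1ccccc1F` likewise gives a limit, > 100000 nM. The steps a step that the two limits leave unreadable from compound 1 to compound 2, a step that the two limits leave unreadable from compound 1 to compound 3 and a step that the two limits leave unreadable from compound 2 to compound 3 therefore cannot be read, since (the limit of > 100000 nM in this assay, at which 3 of the 3 values shown sit). Compound 3 stands with the other two at that limit. Compound 4 `O=S(=O)(Nc1ccc(-c2nc3cc(NS(=O)(=O)c4ccccc4F)ccc3o2)cc1)c1ccccc1F` carries the change (((2-fluorophenyl)sulfonyl)amino in place of hydrogen on an aromatic carbon). Going by the values given here, no measured step bears on this change; the three known steps are all unreadable. The expected step of an at least 1.6-fold lower number from compound 3 to compound 4 (0.22 log units; that floor lies within the scatter) in this assay is small and uncertain in direction. Compound 4 is expected to give 60000 nM in this assay, with a range from 8000 nM to 300000 nM.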

Compound 4, half-maximal inhibitory concentration: 57000 nM
Estimate against measurement, compound 4: 1.1-fold (0.02 log units) above; measured number inside the range.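

Compound 4 is the first compound in the series to give a number rather than a limit in this assay, so this position, on an aromatic carbon para to a large group, is the first shown to move the read-out. Placing ((2-fluorophenyl)sulfonyl)amino there in place of hydrogen gives an at least 1.7-fold lower number from compound 3 to compound 4 (0.24 log units; that floor lies within the scatter) and fixes only a floor, so the true size of the step stays unknown. The earlier steps remain unreadable: the limit of > 100000 nM in this assay, at which 3 of the 4 values shown sit.

Open, as far as these compounds go, is whether a simple amine or an acetamide at this position would also give a number. Also open, from the compounds shown here alone, is whether the 3-fluorophenyl or 4-vinylphenyl sulfonyl groups would behave like the 2-fluorophenyl one here.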